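The source may hold more compounds than are shown below. What is called first, only, known or untested is meant among the compounds shown, and "the series" means these compounds.

Compound 1 `O=C(CSC(=S)N[C@H]1CCOC1=O)Nc1ccc(Br)cc1`: 42800 nM
Compound 2 `O=C(CCl)Nc1ccc(C(=O)/C=C/c2ccc(Cl)cc2)cc1`: 4960 nM
Compound 3 `O=C(CCl)Nc1ccc(C(=O)/C=C/c2ccc(Br)cc2)cc1`: 6050 nM

All three numbers come from a functional assay on MGC-803 cells (Homo sapiens) for cytotoxicity, read by MTT assay, with a stated time of 72 h; a lower number here means a stronger inhibitor, a higher number a weaker inhibitor. In this assay compound 3 gives 6050 nM, which cannot be told apart from compound 2 at 4960 nM, while compound 1 stands clearly higher at 42800 nM.

The next compound to be tested is compound 4 `O=C(CCl)Nc1ccc(C(=O)/C=C/c2cccc(Cl)c2)cc1`, which has not yet been measured. It differs from compound 3 by one change: 3-chlorophenyl in place of 4-bromophenyl on a double-bonded chain carbon bound to a double-bonded chain carbon.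

Within the data shown here, the only measured step that bears on this change is a 1.2-fold higher number from compound 2 to compound 3 (0.09 log units; within the scatter), where bromo replaces chloro on an aromatic carbon. That step tells only of swapping one halogen for the other, and it stayed within the scatter. Among the measured compounds shown here, no measured compound carries the 3-chlorophenyl group, so that part of the change is untested and the range has to stay wide.

No shift beyond the scatter is expected, and the estimated step is a 1.1-fold lower number from compound 3 to compound 4 (0.04 log units; within the scatter). For compound 4 the expected value is 5500 nM, with an estimated range of 2200 nM to 13000 nM.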

Compound 4, half-maximal inhibitory concentration: 2010 nM
Beside the measured number, compound 4's estimate is 2.7-fold (0.44 log units) above it, and the stated range ends above it.
By their numbers in this assay, from the lowest: compound 4; then compounds 2 and 3 (each within the scatter of the next); then compound 1.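

In this assay the group on the double-bonded chain carbon proves more sensitive than the earlier halogen swap suggested: with the halogen kept the same, 3-chlorophenyl in place of 4-chlorophenyl gives a 2.5-fold lower number from compound 2 to compound 4 (0.39 log units; beyond the scatter) and so moves the number beyond the scatter. Replacing 4-bromophenyl with 3-chlorophenyl gives a 3.0-fold lower number from compound 3 to compound 4 (0.48 log units; beyond the scatter) as well, but this step changes the halogen along with the numbering in the group's name, so it cannot separate the two changes by itself. No measurement shown here explains why 3-chlorophenyl gives the lower number.

The compounds shown do not tell whether 3-bromophenyl would match 3-chlorophenyl, or how an unsubstituted phenyl or a phenyl carrying a methoxy or an amine would compare. They also leave open whether the same step would appear in other cell lines.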